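A few compounds are considered here, and "the series" means these few. Any claim that something is new, unique, unknown or untested is made for them only; others in the source may bear on it.

Compound 1 `O=C(/C=C/c1cccc(/C=C/C(=O)c2ccccc2)n1)NO` and compound 3 `O=C(/C=C/c1ccc(/C=C/C(=O)c2ccccc2)cn1)NO` are built from the same atoms joined differently; the difference between the two cores is not broken down here. In a physicochemical assay for solubility, at pH 7.4 (on this read-out lower numbers stand for lower solubility and higher numbers for higher solubility), compound 1 gives 16000 nM, while compound 3 gives 27000 nM, and these two numbers lie within the scatter of each other. Compound 2 `CN1CCN(c2ccccc2C(=O)/C=C/c2cccc(/C=C/C(=O)NO)n2)CC1` carries 4-methylpiperazin-1-yl in place of hydrogen on an aromatic carbon on the core of compound 1; in this assay compound 2 gives 450000 nM, and this change produced a 28-fold higher number from compound 1 to compound 2 (1.45 log units; beyond the scatter) in this assay. Compound 4 `CN1CCN(c2ccc(C(=O)/C=C/c3ccc(/C=C/C(=O)NO)nc3)cc2)CC1` carries 4-methylpiperazin-1-yl in place of hydrogen on an aromatic carbon on the core of compound 3. The group is the same, but in compound 2 it sits ortho to a large group and in compound 4 para to a large group, so the change is of the same kind rather than the same. Compound 4 is expected to show a 15-fold higher number from compound 3 to compound 4 (1.17 log units; beyond the scatter) in this assay, a step of similar size to the earlier one, because compound 2 showed a 28-fold higher number from compound 1 to compound 2 (1.45 log units; beyond the scatter) with the same entering group on a closely related core. The estimate for compound 4 in this assay is 400000 nM, with a range from 100000 nM to 1200000 nM.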

Compound 4, solubility: 29000 nM
For compound 4 the middle estimate is 14-fold (1.14 log units) above the measured one; measured number below the stated range.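

In this assay, 4-methylpiperazin-1-yl in place of hydrogen on the core of compound 3 gives a 1.1-fold higher number from compound 3 to compound 4 (0.03 log units; within the scatter), whereas the same exchange on the core of compound 1 gave a 28-fold higher number from compound 1 to compound 2 (1.45 log units; beyond the scatter). This shows that, in this pair of steps, the large step seen on one core did not carry over to the other: the first step lies within the scatter and the second beyond it. It does not show whether the core or the place of the group decides this, as compound 4 carries the group para to a large group and compound 2 carries it elsewhere, and nothing shown here bears on why the two steps part.

The compounds shown leave open what the same group does when it stands in one place on both cores. They also leave open whether another amine, such as morpholin-4-yl or dimethylamino, would follow compound 2 or compound 4 on these cores.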